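From 4-bromophenyl to 4-chlorophenyl: a small swap

The compounds below may be only part of what the source reports. "The series", "measured", "known", "first", "only" and "open" are said of these compounds alone.

In a functional assay on HepG2 cells (Homo sapiens) for cytotoxicity, read by MTT assay, with a stated time of 72 h (a lower number here means a stronger inhibitor, a higher number a weaker inhibitor), compound 3 `CNC(=O)c1cc(Oc2ccc(C3CC(c4ccc(Br)cc4)=NN3)cc2)ccn1` gives 16900 nM. Within the data shown here, its only measured neighbour, compound 2 `CNC(=O)c1cc(Oc2ccc(C3CC(c4ccc([N+](=O)[O-])cc4)=NN3)cc2)ccn1`, gives 28900 nM. The step between them is a 1.7-fold lower number from compound 2 to compound 3 (0.23 log units; within the scatter), so the two cannot be told apart and compound 3 holds no clear place of its own. Compound 1 `CNC(=O)c1cc(Oc2ccc(C3=NNC(c4ccc(Cl)cc4Cl)C3)cc2)ccn1` offers no comparison, since its entry reads "not determined" (no result reported).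

Compound 4 `CNC(=O)c1cc(Oc2ccc(C3CC(c4ccc(Cl)cc4)=NN3)cc2)ccn1` differs from compound 3 at one place: chloro in place of bromo on an aromatic carbon. It carries chloro in place of bromo on an aromatic carbon, para to a large group, turning the 4-bromophenyl into 4-chlorophenyl.

Among the measured compounds shown here, no measured pair makes this exact swap. The nearest evidence is bromo in place of nitro on an aromatic carbon, which gave a 1.7-fold lower number from compound 2 to compound 3 (0.23 log units; within the scatter). Even that swap of two quite different groups stayed within the scatter, so no step beyond the scatter is expected in this assay here.

The estimated step is a 1.1-fold higher number from compound 3 to compound 4 (0.03 log units; within the scatter). Compound 4 is expected to give about 18000 nM, with an estimated range of 9000 nM to 34000 nM.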

Compound 4, half-maximal inhibitory concentration: 10900 nM
Compound 4: the middle estimate sits 1.7-fold (0.22 log units) above what was measured; the measured number falls inside the stated range.
By their numbers in this assay, from the lowest: compounds 4, 3 and 2 (each within the scatter of the next, the first and the last beyond it).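

In this assay the step of a 1.6-fold lower number from compound 3 to compound 4 (0.19 log units; within the scatter) stays within the scatter, so bromo and chloro at this place on the ring cannot be told apart. The change from nitro to chloro gives the only step among these compounds that goes beyond the scatter, a 2.7-fold lower number from compound 2 to compound 4 (0.42 log units; beyond the scatter), which shows that the group at this place can shift the number, though only modestly, and compound 2 and compound 3 still cannot be separated. Nothing shown here gives a measured reason for this small difference.

On these data alone, it remains open whether fluoro would read like bromo and chloro, and whether an amine, a methoxy group or a carboxylic acid at this place would shift the number further. As far as these compounds go, it also remains open whether any group here can bring the number far below those seen so far.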